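Swapping a cyanomethyl for an aryl amide on the core

The source may hold more compounds than are shown below. What is called first, only, known or untested is meant among the compounds shown, and "the series" means these compounds.

In a physicochemical assay for solubility (on this read-out higher numbers stand for higher solubility and lower numbers for lower solubility), compound 2 `N#CCn1c(=O)n(-c2ccc(C#N)c(C(F)(F)F)c2)c2ccccc21` gives 18900 nM, the highest of the two numbers shown. Compound 1 `N#Cc1ncc(-n2c(=O)n(Cc3ccccc3)c3ccccc32)cc1C(F)(F)F` gives 5300 nM, a step below compound 2 that lies beyond the usual scatter. Compound 3 `N#Cc1ccc(-n2c(=O)n(Cc3ccccc3)c3cccnc32)cc1C(F)(F)F` gives only a limit, < 500 nM, which is the limit of < 500 nM in this assay, at which 1 of the 3 values shown sits. Compound 4 `CNC(=O)c1ccc(-n2c(=O)n(-c3ccc(C#N)c(C(F)(F)F)c3)c3ccccc32)cc1F` is not yet measured; it differs from compound 2 by 3-fluoro-4-(methylcarbamoyl)phenyl in place of cyanomethyl on an aromatic nitrogen. Among the measured compounds shown here, no measured pair shows this change, so the size of its step is open. The step is expected to be downward and beyond the scatter, a 6.3-fold lower number from compound 2 to compound 4 (0.80 log units; beyond the scatter). Compound 4 is estimated to give 3000 nM, with a range from 700 nM to 12000 nM.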

Compound 4, solubility: 8810 nM
Compound 4: middle estimate off by 2.9-fold (0.47 log units), on the low side; the measured number falls inside the stated range.
By their numbers in this assay, from the lowest: compounds 1 and 4 (each within the scatter of the next); then compound 2. At a limit, below all of these: compound 3.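

In this assay, the substituent on the aromatic nitrogen now has its first measured pair: 3-fluoro-4-(methylcarbamoyl)phenyl in place of cyanomethyl gives a 2.1-fold lower number from compound 2 to compound 4 (0.33 log units; beyond the scatter). The step is modest, although the entering group brings an aromatic ring and the amide hydrogen, and compound 4 still gives a number and not a limit. On these data alone, whether an amine or a carboxylic acid on that nitrogen would give a similar step stays open, as does how much of this step belongs to the fluorine and how much to the methylcarbamoyl. Nothing shown gives a reason for the step.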